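A few compounds are considered here, and "the series" means these few. Any claim that something is new, unique, unknown or untested is made for them only; others in the source may bear on it.

Measured compounds:
compound 1, `O=C(/C=C/c1ccc(OCc2cn(Cc3ccccc3Br)nn2)cc1)c1ccc(Br)cc1`, 43%
compound 2, `O=C(/C=C/c1ccc(OCc2cn(Cc3ccccc3Br)nn2)cc1)c1ccc([N+](=O)[O-])cc1`, 34%

Both numbers come from a functional assay on MIA PaCa-2 cells (Homo sapiens) for inhibition, read by MTT assay, with a stated time of 48 h, tested at 10 uM; on this read-out higher numbers stand for more inhibition of growth at the one concentration tested and lower numbers for less inhibition of growth. Going by the values given here, only two compounds have been measured, so compound 2 has a single comparator, compound 1, and the one measured step is a number 9 percentage points lower from compound 1 to compound 2 (within the scatter); the two numbers are not separable on this read-out.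

Compound 3, `O=C(/C=C/c1ccc(OCc2cn(Cc3cccc(F)c3)nn2)cc1)c1ccc([N+](=O)[O-])cc1`, has not been measured. It differs from compound 2 in 3-fluorophenyl in place of 2-bromophenyl on a saturated chain carbon bound to an aromatic nitrogen. Among the compounds with values here, the one measured step concerns the aryl ketone end of the shared core, not the benzyl group on the triazole nitrogen, so no measured step bears directly on this change. With a different part of the molecule varied there, and that variation itself staying within the scatter, the working expectation for the exchange of the benzyl substituent is a step of no size beyond the scatter in this assay, in either direction.

The expected step from compound 2 is therefore a number 1 percentage points higher from compound 2 to compound 3 (within the scatter). For compound 3 the estimate in this assay is 35%, with a range from 20% to 50%.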

Compound 3, percent growth inhibition at one concentration: 32%
Compound 3: middle estimate off by 3 percentage points, on the high side; measured number inside the range.
By their numbers in this assay, from the lowest: compounds 3, 2 and 1 (each within the scatter of the next, the first and the last beyond it).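

Working notes on the series. In this assay, going by these compounds alone, the exchange of 2-bromophenyl for 3-fluorophenyl on a saturated chain carbon bound to an aromatic nitrogen gives a number 2 percentage points lower from compound 2 to compound 3 (within the scatter) and is the first measured step at this position, whereas the earlier step, a number 9 percentage points lower from compound 1 to compound 2 (within the scatter), concerned nitro in place of bromo on an aromatic carbon. For this one pair, with the rest of compound 2 kept, the change of both the halogen and its printed place on the phenyl ring leaves the two numbers not separable, so the position has so far shown no step beyond the scatter. Nothing measured speaks to why this is so.

Within the data shown here, the single exchange alters the halogen and its place together, so the contribution of each stays unresolved, and one pair cannot show whether the position tolerates change in general. Also open, going by these compounds, is whether a phenyl ring bearing an amine or a carboxylic acid, or a longer alkyl chain in place of the phenyl ring, would give a step beyond the scatter at this position.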